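Replacing the chlorophenyl amide with a trifluoromethylpyridinyl amide

The compounds below may be only part of what the source reports. "The series", "measured", "known", "first", "only" and "open" are said of these compounds alone.

Measured compounds:
compound 1 `CCOC(=O)c1sc(-c2cccc(NC(=O)c3ccccc3F)c2)nc1Nc1ccc(N2CCN(C)CC2)cc1` gives 89.8%
compound 2 `CCOC(=O)c1sc(-c2cccc(NC(=O)c3ccc(Cl)cc3)c2)nc1Nc1ccc(N2CCN(C)CC2)cc1` gives 24.3%

In a functional assay on Raji cells (Homo sapiens) for antiproliferative activity, read by CCK-8 assay, with a stated time of 72 h, tested at 40 uM (a higher number here means more inhibition at the concentration tested (going by the name of the read-out), a lower number less inhibition), compound 2 stands lowest of the two numbers shown; its nearest neighbour is compound 1, which gives 89.8%, and the step of a number 65.5 percentage points lower from compound 1 to compound 2 (beyond the scatter) is large and beyond the scatter. Going by the values given here, the only measured step thus concerns the group on the carbonyl carbon of the amide, where 4-chlorophenyl replaced 2-fluorophenyl.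

Compound 3 `CCOC(=O)c1sc(-c2cccc(NC(=O)c3ccc(C(F)(F)F)cn3)c2)nc1Nc1ccc(N2CCN(C)CC2)cc1` is not yet measured. It differs from compound 2 in one place: 5-(trifluoromethyl)pyridin-2-yl in place of 4-chlorophenyl on a carbonyl carbon. Among the compounds with values here, no measured step covers this particular exchange; the step from compound 1 to compound 2 shows only that this amide group can move the read-out strongly, in either direction. The direction for compound 3 cannot be inferred, so a wide range is expected. Compound 3 is estimated at 45%, between 15% and 80%, which means an expected step of a number 20.7 percentage points higher from compound 2 to compound 3 (beyond the scatter).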

Compound 3, a percentage reported as inhibition, at one concentration (the size of the read-out at that concentration, not a potency): 20.8%
Beside the measured number, compound 3's estimate is 24.2 percentage points above it, and the stated range covers the measured number.
By their numbers in this assay, from the lowest: compounds 3 and 2 (each within the scatter of the next); then compound 1.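

In this assay, the exchange of 4-chlorophenyl for 5-(trifluoromethyl)pyridin-2-yl on the carbonyl carbon gives a number 3.5 percentage points lower from compound 2 to compound 3 (within the scatter). This read-out therefore does not separate these two groups, although the entering group has a ring hetero atom, a hydrogen-bond acceptor and more heavy atoms. The second new step, a number 69 percentage points lower from compound 1 to compound 3 (beyond the scatter), shows that among these three compounds the 2-fluorophenyl group of compound 1 stands apart from both other aromatic groups, not only from 4-chlorophenyl. No evidence at hand accounts for this separation.

Still open, on these data alone, is how an unsubstituted phenyl ring or a saturated amine such as piperidine would read on the same carbonyl carbon. As far as these compounds go, it is also open whether the 2-fluorophenyl result would hold with a carboxylic acid in place of the ethyl ester.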